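The source may report more compounds than this note shows. Statements on the series, on what has been measured and on what is new or still open speak of the compounds shown alone.

Compound 1 `Cc1cc(C)cc(S(=O)(=O)c2c(C(=O)NC(c3ccc(Cl)cc3)C3CC3)[nH]c3ccc(Cl)cc23)c1`: > 47300 nM
Compound 2 `Cc1cc(C)cc(S(=O)(=O)c2c(C(=O)NCC(=O)NCCn3c(C)cnc3[N+](=O)[O-])[nH]c3ccc(Cl)cc23)c1`: 24500 nM

In an ADME assay on MT4 cells (Homo sapiens) for cytotoxicity, read by MTT assay (on this read-out higher numbers stand for lower toxicity in this test and lower numbers for higher toxicity in this test), compound 1 gives > 47300 nM, which is a limit and not a number. Compound 2 gives a true number, 24500 nM. Compound 3 `Cc1cc(C)cc(S(=O)(=O)c2c(C(=O)NCc3ccc4nc(N)[nH]c4c3)[nH]c3ccc(Cl)cc23)c1` keeps the core of compound 1 and changes the group on an amide-type nitrogen: a group of 11 heavy atoms (8 carbon, 3 nitrogen; one five-membered aromatic ring with 2 hetero atoms, one six-membered aromatic ring of carbon only) in place of a group of 11 heavy atoms (10 carbon, 1 chlorine; one three-membered non-aromatic ring of carbon only, one six-membered aromatic ring of carbon only), on an amide-type nitrogen. Within the data shown here, no measured pair shows this change. A moderate move toward lower numbers in this assay is therefore expected, with an estimated step of an at least 2.1-fold lower number from compound 1 to compound 3 (0.33 log units; beyond the scatter). For compound 3 the expected value is 22000 nM, with an estimated range from 7000 nM to 60000 nM.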

Compound 3, half-maximal cytotoxic concentration: 5890 nM
Compound 3: middle estimate off by 3.7-fold (0.57 log units), on the high side, and the stated range ends above it.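

In this assay, among these compounds, the exchange on the amide-type nitrogen gives an at least 8.0-fold lower number from compound 1 to compound 3 (0.90 log units; beyond the scatter), the first step that can be read at this place. Both groups hold 11 heavy atoms, so the read-out here follows what the group is made of, not its heavy-atom count alone. The size of the step is only a minimum: the limit of > 47300 nM in this assay, at which 1 of the 3 values shown sits.

The compounds shown leave open which part of the entering group carries the step. They also leave open how a plain benzyl group or a carboxylic acid on this nitrogen would read.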